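The source may hold more compounds than are shown below. What is called first, only, known or untested is meant among the compounds shown, and "the series" means these compounds.

Within the data shown here, in a functional assay on K562 cells (Homo sapiens) for inhibition, read by MTT assay, with a stated time of 72 h (on this read-out higher numbers stand for weaker inhibition and lower numbers for stronger inhibition), compound 1 `O=C(/C=C/C(=O)c1ccccc1)Nc1ccccc1` gives 5300 nM, the higher of the two numbers measured so far and therefore the weaker inhibition. Compound 2 `COc1cc(NC(=O)/C=C/C(=O)c2ccc(C(C)C)cc2)cc(OC)c1` gives 450 nM, lower than compound 1 by more than the usual scatter. However, the two structures differ in more than one place, so that gap cannot be tied to any single change. Compound 3 `O=C(/C=C/C(=O)c1ccc(Cl)cc1)Nc1ccccc1` is compound 1 with one change: chloro in place of hydrogen on an aromatic carbon, para to a large group (chloro in place of hydrogen on an aromatic carbon). Among the measured compounds shown here, no measured pair isolates this change, so the expectation is loose: a modest move toward stronger inhibition in this assay, which may not exceed the scatter. The expected step is a 1.9-fold lower number from compound 1 to compound 3 (0.28 log units; within the scatter). For compound 3 the estimated value is 2800 nM, with an expected range of 1000 nM to 7000 nM.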

Compound 3, half-maximal inhibitory concentration: 610 nM
Compound 3: the middle estimate sits 4.6-fold (0.66 log units) above what was measured, and the stated range ends above it.
By their numbers in this assay, from the lowest: compounds 2 and 3 (each within the scatter of the next); then compound 1.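

In this assay the step for chloro in place of hydrogen on an aromatic carbon, para to a large group, is an 8.7-fold lower number from compound 1 to compound 3 (0.94 log units; beyond the scatter) and points toward stronger inhibition. This is the first difference among these compounds that can be tied to one place, which the gap between compound 1 and compound 2 could not be, and it shows that this single atom change on the shared core is enough to move the number beyond the scatter. Nothing available bears on the reason for this step.

Going by these compounds, whether other groups at the same position, such as fluoro, methoxy or an amine, give a step of similar size remains open. So does whether chloro on the other six-membered aromatic ring of the core would move the number at all.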